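Hydroxy-to-fluoro swap on two cores, all at the limit

A few compounds are considered here, and "the series" means these few. Any claim that something is new, unique, unknown or untested is made for them only; others in the source may bear on it.

Compound 1 `COc1nc(CC(O)(COC(C)=O)COC(C)=O)c(C)c(OC)n1` and compound 2 `COc1nc(CC(F)(COC(C)=O)COC(C)=O)c(C)c(OC)n1` share one core; compound 3 `CC(=O)OCC(O)(COC(C)=O)Cc1c(C)c(=O)[nH]c(=O)n1C` and compound 4 `CC(=O)OCC(F)(COC(C)=O)Cc1c(C)c(=O)[nH]c(=O)n1C` share another. The difference between the two cores is not broken down here. Within each pair the change is the same: fluoro in place of hydroxy on a saturated chain carbon bound to three saturated chain carbons in the first pair and fluoro in place of hydroxy on a saturated chain carbon bound to three saturated chain carbons in the second, the place being described in identical words both times.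

In a functional assay on HeLa cells (Homo sapiens) for antiproliferative activity, read by MTT assay, with a stated time of 72 h (a higher number here means a weaker inhibitor, a lower number a stronger inhibitor), compound 1 gives > 100000 nM, which is a limit of the assay and not a number. Compound 2 gives > 100000 nM in this assay, again a limit. The step that the two limits leave unreadable from compound 1 to compound 2 is therefore of unreadable size. Compound 3 gives > 100000 nM in this assay, also a limit. All three values rest at the limit of > 100000 nM in this assay, at which 3 of the 3 values shown sit.

For the measured compounds named here, for compound 4 the only guide is that the same change gave a step that the two limits leave unreadable from compound 1 to compound 2, with both ends at the limit, so the step that the limit leaves unreadable from compound 3 to compound 4 is expected to be small and compound 4 is expected to remain at the limit as well. Compound 4 is estimated at 150000 nM in this assay, with an expected range from 50000 nM to 500000 nM, and most likely the assay again reports only a limit rather than a number.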

Compound 4, half-maximal inhibitory concentration: > 100000 nM
Compound 4 gave a limit, no number (the forecaster's own chance of this, stated with the estimate: 90%); the middle value lies beyond the limit too.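

In this assay compound 4 gives > 100000 nM as a limit and not a number. The steps from compound 3 to compound 4 and from compound 1 to compound 2 therefore cannot be read, with every value resting at the same limit: the limit of > 100000 nM in this assay, at which 4 of the 4 values shown sit.

The compounds shown leave open whether fluoro in place of hydroxy changes antiproliferative activity on either core.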